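Swapping the Aryl Ketone on a Shared Core

The source may hold more compounds than are shown below. What is called first, only, known or untested is meant among the compounds shown, and "the series" means these compounds.

Compound 2 `COc1cc(C(=O)C2Sc3nnc(-c4cc(OC)c(OC)c(OC)c4)n3NC2c2ccco2)cc(OC)c1OC` gives 52200 nM in a functional assay on PC-3 cells (Homo sapiens) for cytotoxicity, read by MTT assay, with a stated time of 48 h; on this read-out lower numbers stand for stronger inhibition and higher numbers for weaker inhibition. Its companion, compound 1 `COc1cc(-c2nnc3n2NC(c2ccco2)C(C(=O)c2ccccc2C)S3)cc(OC)c1OC`, gives 88400 nM in this assay, and a 1.7-fold lower number from compound 1 to compound 2 (0.23 log units; within the scatter) separates the two, so neither can be set apart from the other. Compound 3 `COc1cc(-c2nnc3n2NC(c2ccco2)C(C(=O)c2ccccc2F)S3)cc(OC)c1OC` carries 2-fluorophenyl in place of 3,4,5-trimethoxyphenyl on a carbonyl carbon. Going by the values given here, the only measured step at this carbonyl position, a 1.7-fold lower number from compound 1 to compound 2 (0.23 log units; within the scatter), stayed within the scatter, so no change beyond the scatter is expected and the anticipated step is a 1.5-fold higher number from compound 2 to compound 3 (0.19 log units; within the scatter). Compound 3 is therefore estimated at 80000 nM, with a range from 30000 nM to 200000 nM.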

Compound 3, half-maximal inhibitory concentration: > 100000 nM
Compound 3 ended at the assay's limit; the forecaster's own chance of this, stated with the estimate: 20%; middle value at least 1.2-fold (0.09 log units) away from the limit.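

Compound 3 sits at a limit of this assay, so its reading is not a number: the limit of > 100000 nM in this assay, at which 1 of the 3 values shown sits. Placing 2-fluorophenyl on the carbonyl carbon gives an at least 1.9-fold higher number from compound 2 to compound 3 (0.28 log units; that floor lies within the scatter), and the single swap of fluoro for methyl on an aromatic carbon gives an at least 1.1-fold higher number from compound 1 to compound 3 (0.05 log units; that floor lies within the scatter). Going by these compounds alone, both are only floors, so the true sizes of these steps remain unknown, and no step at this position yet lies beyond the scatter.

As far as these compounds go, whether any group here can bring a clear gain stays open. An aminophenyl or a carboxylic acid on this carbonyl carbon could test that.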